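The source may report more compounds than this note shows. Statements on the series, on what has been measured and on what is new or still open speak of the compounds shown alone.

Measured so far in an in vitro ADME assay on microsomes from liver (Homo sapiens) for metabolic stability; on this read-out lower numbers stand for slow clearance and higher numbers for fast clearance:
compound 1, `Cc1ccc(C(=O)N2CCC(=CC(=O)N[C@@H]3CCN(Cc4ccc5cc(F)ccc5c4)C3)CC2)c(O)c1`, gives 156 mL/min/kg
compound 2, `COc1cccc(C(=O)N2CCC(=CC(=O)N[C@@H]3CCN(Cc4ccc5cc(F)ccc5c4)C3)CC2)c1`, gives 500 mL/min/kg
compound 3, `O=C(C=C1CCN(C(=O)c2ccccc2O)CC1)N[C@@H]1CCN(Cc2ccc3cc(F)ccc3c2)C1`, gives only a limit of the assay, < 64 mL/min/kg; see (the limit of < 64 mL/min/kg in this assay, at which 1 of the 3 values shown sits).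

Compound 2 stands at the highest of the two numbers, compound 1 being the nearest: a 3.2-fold higher number from compound 1 to compound 2 (0.51 log units; beyond the scatter). Compound 4, `O=C(C=C1CCN(C(=O)c2ccccc2F)CC1)N[C@@H]1CCN(Cc2ccc3cc(F)ccc3c2)C1`, differs from compound 2 at the same place where compound 3 does: 2-fluorophenyl in place of 3-methoxyphenyl on a carbonyl carbon. Going by the values given here, the steps that bear on it are an at least 7.8-fold lower number from compound 2 to compound 3 (0.89 log units; beyond the scatter) and an at least 2.4-fold lower number from compound 1 to compound 3 (0.38 log units; beyond the scatter), both lowering the number. A modest lowering from compound 2 is therefore expected, a 2.5-fold lower number from compound 2 to compound 4 (0.40 log units; beyond the scatter), though the step to compound 4 removes a group rather than adding a hydroxyl, so the size is uncertain. Compound 4 is estimated at 200 mL/min/kg, between 80 mL/min/kg and 500 mL/min/kg.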

Compound 4, clearance: 590 mL/min/kg
Compound 4: middle estimate off by 3.0-fold (0.47 log units), on the low side; the whole stated range lies below it.
By their numbers in this assay, from the lowest: compound 1; then compounds 2 and 4 (each within the scatter of the next). At a limit, below all of these: compound 3.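

At the carbonyl carbon, 2-fluorophenyl and 3-methoxyphenyl cannot be told apart in this assay (a 1.2-fold higher number from compound 2 to compound 4 (0.07 log units; within the scatter)). Fluoro in place of hydroxy gives a clear change (an at least 9.2-fold higher number from compound 3 to compound 4 (0.96 log units; beyond the scatter)), and compound 4 also separates from the hydroxy-bearing compound 1 (a 3.8-fold higher number from compound 1 to compound 4 (0.58 log units; beyond the scatter)), so among these compounds the lower numbers go with a hydroxy group on the aryl ring, not with just any group there. Compound 3 gives only a limit of the assay: the limit of < 64 mL/min/kg in this assay, at which 1 of the 4 values shown sits.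

As far as these compounds go, whether 2-aminophenyl or 2-methoxyphenyl at this place would also give a low number stays open.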